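Working notes on the step from compound 3 to compound 4

The source may hold more compounds than are shown below. What is called first, only, known or untested is meant among the compounds shown, and "the series" means these compounds.

Measured so far:
compound 1 `O=c1c(Cl)c(CSC(=S)N2CCOCC2)oc2ccccc12`: 4100 nM
compound 2 `O=c1c(CSC(=S)N2CCCCC2)coc2cc(Cl)ccc12`: 240 nM
compound 3 `O=c1c(Cl)c(CSC(=S)N2CCCC2)oc2ccccc12`: 1800 nM

All numbers come from a functional assay on MDA-MB-435S cells (Homo sapiens) for antiproliferative activity, read by MTT assay, with a stated time of 72 h; a higher number here means a weaker inhibitor, a lower number a stronger inhibitor. Compound 3 stands second highest of the three; its nearest neighbour is compound 1, the step being a 2.3-fold lower number from compound 1 to compound 3 (0.36 log units; beyond the scatter), while compound 2, which differs from compound 3 in more than one place, gives a clearly lower number. The change to compound 4 `O=c1cc(CSC(=S)N2CCCC2)oc2ccccc12` is hydrogen in place of chloro on an aromatic carbon. For the measured compounds named here, no measured step touches this position: the single one-place step, from compound 1 to compound 3, concerns the amine on the thiocarbonyl carbon and was modest. Going by the values given here, with no precedent, no step beyond the scatter is expected; the expected step is a 1.4-fold higher number from compound 3 to compound 4 (0.14 log units; within the scatter). Compound 4 is estimated at 2500 nM, range 800 nM to 8000 nM.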

Compound 4, half-maximal inhibitory concentration: > 30000 nM
Compound 4 ended at the assay's limit; the forecaster's own chance of this, stated with the estimate: 5%; at least 12-fold (1.07 log units) between middle value and limit.
By their numbers in this assay, from the lowest: compound 2; then compound 3; then compound 1. At a limit, above all of these: compound 4.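

For the compounds shown here, replacing chloro with hydrogen on this aromatic carbon gives an at least 16-fold higher number from compound 3 to compound 4 (1.22 log units; beyond the scatter), so this position carries far more of the activity than the earlier compounds could show. Going by these compounds alone, the only earlier one-place step, a 2.3-fold lower number from compound 1 to compound 3 (0.36 log units; beyond the scatter), concerned the amine on the thiocarbonyl carbon and was modest. In this assay compound 4 gives > 30000 nM, which is a limit and not a number: the limit of > 30000 nM in this assay, at which 1 of the 4 values shown sits.

From the compounds shown here alone, whether fluoro, bromo or methyl on this carbon would keep the activity of the chloro stays open. Also open, going by these compounds, is whether removing chloro costs as much with the morpholin-4-yl group of compound 1.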